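This account rests on a few compounds, and the source may have more. Where it says the series, first, only, none or still open, it means among the compounds named here.

In a functional assay on PC-3M cells (Homo sapiens) for antiproliferative activity, read by microscopy, with a stated time of 24 h (on this read-out higher numbers stand for weaker inhibition and lower numbers for stronger inhibition), compound 3 (`COc1ccc(-c2c(-c3ccc(OC)cc3)n(Cc3ccccc3)c3ncn(CCO)c(=N)c23)cc1`) gives > 20000 nM, which is a limit of the assay and not a number, and its further entries also give no single number. Compound 4 (`COc1ccc(-c2c(-c3ccc(OC)cc3)n(Cc3ccccc3)c3ncn(C4CCOCC4)c(=N)c23)cc1`) carries oxan-4-yl in place of 2-hydroxyethyl on an aromatic nitrogen. Among the compounds with values here, no measured pair isolates this change. Compound 1 (`COc1ccc(Cn2c(-c3ccccc3)c(-c3ccccc3)c3c(=N)n(C4CCOCC4)cnc32)cc1`) also has oxan-4-yl there, with other groups differing, and gives 170 nM; 174 nM (2 entries). Compound 2 (`N=c1c2c(-c3ccccc3)c(-c3ccccc3)n(CC3CCCCC3)c2ncn1CCCO`), with 3-hydroxypropyl there, gives 27700 nM; 26900 nM (2 entries). On the strength of these values, a large expected gain towards stronger inhibition, well beyond the scatter, is an at least 33-fold lower number from compound 3 to compound 4 (1.52 log units; beyond the scatter). The estimate for compound 4 is 600 nM, with an expected range of 120 nM to 5000 nM.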

Compound 4, half-maximal inhibitory concentration: > 20000 nM
Compound 4: a limit, no number; the forecaster's own chance of this, stated with the estimate: 12%; middle value at least 33-fold (1.52 log units) away from the limit.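

In this assay, within the data shown here, compound 3 and compound 4 both stand only at limits of the assay, and no step between them can be read. The compounds shown leave open whether oxan-4-yl in place of 2-hydroxyethyl changes inhibition on this shared core.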